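Ethoxy in place of bis(2-hydroxyethyl)amino on a carbonyl carbon

The source may hold more compounds than are shown below. What is called first, only, known or untested is meant among the compounds shown, and "the series" means these compounds.

In a functional assay on SW-620 cells (Homo sapiens) (a higher number here means a weaker inhibitor, a lower number a stronger inhibitor), compound 1 (`COc1cc(NC(C)CCCNC(=O)NCCCO)c2ncccc2c1`) gives > 100000 nM as a limit of the assay. Compound 2 (`COc1cc(NC(C)CCCNC(=O)NC(CO)(CO)CO)c2ncccc2c1`) gives > 100000 nM as a limit too. Compound 3 (`COc1cc(NC(C)CCCNC(=O)N(CCO)CCO)c2ncccc2c1`) likewise gives only a limit of > 100000 nM and so has no readable rank. The evidence is the limit of > 100000 nM in this assay, at which 3 of the 3 values shown sit, and nothing more. The measured changes, a step that the two limits leave unreadable from compound 1 to compound 3 and a step that the two limits leave unreadable from compound 2 to compound 3, offer no size to carry over. Compound 4 (`CCOC(=O)NCCCC(C)Nc1cc(OC)cc2cccnc12`) carries ethoxy in place of bis(2-hydroxyethyl)amino on a carbonyl carbon. Starting from a limit, only a move towards a stronger inhibitor in this assay could be read. The expected change, tentatively, is an at least 1.6-fold lower number from compound 3 to compound 4 (0.22 log units; that floor lies within the scatter). For compound 4 the estimate is 60000 nM with an expected range from 15000 nM to 100000 nM and a reading at the limit remains quite possible.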

Compound 4, half-maximal inhibitory concentration: 45000 nM
Beside the measured number, compound 4's estimate is 1.3-fold (0.12 log units) above it; the range from low to high includes it.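

Among these compounds, at this carbonyl carbon ethoxy gives the first readable number in this assay, and each gain has only a floor: it gives an at least 2.2-fold lower number from compound 3 to compound 4 (0.34 log units; beyond the scatter) against bis(2-hydroxyethyl)amino, an at least 2.2-fold lower number from compound 2 to compound 4 (0.34 log units; beyond the scatter) against (2-hydroxy-1,1-bis(hydroxymethyl)ethyl)amino and an at least 2.2-fold lower number from compound 1 to compound 4 (0.34 log units; beyond the scatter) against (3-hydroxypropyl)amino here. The steps among compound 1, compound 2 and compound 3 cannot be read, as each of these compounds gives only a limit.

The compounds shown do not separate the loss of the hydroxyl groups from the exchange of the amino nitrogen for oxygen. On these data alone, how a plain ethylamino group or a longer butoxy chain on the same carbonyl carbon would read stays open.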